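This account rests on a few compounds, and the source may have more. Where it says the series, first, only, none or still open, it means among the compounds named here.

In a functional assay on DU-145 cells (Homo sapiens) for cytotoxicity, read by MTT assay (on this read-out lower numbers stand for stronger inhibition and higher numbers for weaker inhibition), compound 1 `CC(C)=CC[C@@H](OC(=O)c1ccco1)C1=CC(=O)c2c(O)ccc(O)c2C1=O` gives > 100000 nM as a limit of the assay and not a number. Compound 2 `CC(C)=CC[C@@H](OC[C@@H](C)O)C1=CC(=O)c2c(O)ccc(O)c2C1=O` gives 14300 nM and compound 3 `CC(=O)OCCC(=O)O[C@H](CC=C(C)C)C1=CC(=O)c2c(O)ccc(O)c2C1=O` gives 15700 nM on the same read-out. The step of a 1.1-fold higher number from compound 2 to compound 3 (0.04 log units; within the scatter) lies within the scatter, so these two measured numbers stand level and the only other result is the limit.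

Compound 4 `COCCO[C@H](CC=C(C)C)C1=CC(=O)c2c(O)ccc(O)c2C1=O` has 2-methoxyethyl in place of (2-acetoxyethyl)carbonyl on an oxygen on a saturated carbon. That oxygen carries 2-hydroxypropyl in compound 2 (14300 nM) and (2-acetoxyethyl)carbonyl in compound 3 (15700 nM), and this exchange made no difference beyond the scatter. The steps of an at least 6.9-fold lower number from compound 1 to compound 2 (0.84 log units; beyond the scatter) and an at least 6.3-fold lower number from compound 1 to compound 3 (0.80 log units; beyond the scatter) both start from a limit and give only a minimum size. They also both remove a furan-2-yl group, which compound 4 does not carry.

In this assay no step beyond the scatter is therefore expected, and the estimated step is a 1.2-fold lower number from compound 3 to compound 4 (0.08 log units; within the scatter) with its direction left open. For compound 4 the estimated value is 13000 nM with an expected range (5000 nM to 32000 nM).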

Compound 4, half-maximal inhibitory concentration: 43200 nM
The estimate for compound 4 lay 3.3-fold (0.52 log units) below the measured number; measured number outside the range, above it.
By their numbers in this assay, from the lowest: compounds 2 and 3 (each within the scatter of the next); then compound 4. At a limit, above all of these: compound 1.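

In this assay, the oxygen on a saturated carbon no longer reads as insensitive to its substituent, as the level pair of compound 2 and compound 3 suggested: there is a 2.8-fold higher number from compound 3 to compound 4 (0.44 log units; beyond the scatter), and also a 3.0-fold higher number from compound 2 to compound 4 (0.48 log units; beyond the scatter). Compound 2 and compound 4 differ only in 1-hydroxyethyl against methoxymethyl on the saturated chain carbon bound to that oxygen, so among these compounds a change at that outer part of the chain is enough to move the number, with both steps modest. Compound 1 stands at a limit of the assay and not a number, and an at least 2.3-fold lower number from compound 1 to compound 4 (0.36 log units; beyond the scatter) gives a minimum size only: the limit of > 100000 nM in this assay, at which 1 of the 4 values shown sits.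

With a single pair carrying the 1-hydroxyethyl to methoxymethyl change, the compounds shown cannot separate the effect of the hydroxyl group from that of the position of the chain's oxygen. They also leave open how an amine or a carboxylic acid at the end of this chain, or a longer chain, would read in this assay.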